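Swapping a Fluorophenyl for a Fluoropyridyl

The source may hold more compounds than are shown below. What is called first, only, known or untested is meant among the compounds shown, and "the series" means these compounds.

Of the compounds shown here, three have been measured in an assay on cells for inhibition of sodium- and chloride-dependent glycine transporter 1 (Homo sapiens); on this read-out higher numbers stand for an effect only at larger amounts of compound and lower numbers for an effect already at smaller amounts. Compound 1 `COc1cc(C(F)(F)F)cc(C(F)(F)F)c1C(=O)NC1(c2ccccc2)CCCN(C2CCCC2)C1` gives 270 nM, compound 2 `COc1cc(C(F)(F)F)ccc1C(=O)NC1(c2ccccc2)CCCN(C)C1` gives 4800 nM, and compound 3 `COc1cc(C(F)(F)F)cc(SC)c1C(=O)NC1(c2ccc(F)cc2)CCCN(C)C1` gives 26 nM. Compound 3 therefore has the lowest number of the three: its distance to compound 1, the nearest, and to compound 2, the furthest, both lie beyond the usual scatter, so compound 3 is the most potent of the measured compounds.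

Compound 4 `COc1cc(C(F)(F)F)cc(SC)c1C(=O)NC1(c2ccc(F)cn2)CCCN(C)C1` has not yet been measured. It differs from compound 3 in a single place: 5-fluoropyridin-2-yl in place of 4-fluorophenyl on a saturated ring carbon. Everything else in the molecule stays the same. Within the data shown here, no pair of measured compounds differs in just this way, so the data give no direct guide to how far such a swap moves the number. The step of a 1.9-fold higher number from compound 3 to compound 4 (0.28 log units; within the scatter) is expected to be small, possibly a slight move toward a higher number, but not beyond the scatter. The estimate for compound 4 in this assay is 50 nM, with a range from 15 nM to 170 nM.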

Compound 4, half-maximal effective concentration: 180 nM
Compound 4: middle estimate off by 3.6-fold (0.56 log units), on the low side, and the stated range ends below it.
By their numbers in this assay, from the lowest: compound 3; then compounds 4 and 1 (each within the scatter of the next); then compound 2.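

Among these compounds, this is the first pair in the set that differs in only one place, so the effect of a single change can now be read directly. In this assay there is a 6.9-fold higher number from compound 3 to compound 4 (0.84 log units; beyond the scatter) when 5-fluoropyridin-2-yl replaces 4-fluorophenyl, a step beyond the scatter, even though the two groups have the same number of heavy atoms and both carry fluorine; at this saturated ring carbon, then, replacing one aromatic ring carbon with nitrogen and adding one hydrogen-bond acceptor is enough to weaken the compound measurably. Nothing available explains why the number rises.

A single pair cannot show whether other aromatic rings at this carbon, such as 4-chlorophenyl or a pyrimidin-2-yl ring, would be tolerated better or worse. It also leaves open whether the same swap would have a similar effect with a cyclopentyl group in place of the methyl on the ring nitrogen.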